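The compounds below may be only part of what the source reports. "The series", "measured", "known", "first", "only" and "open" are said of these compounds alone.

Compound 1, `CCCCOC(=O)CNC(=O)[C@H](CSc1ccc([N+](=O)[O-])cc1[N+](=O)[O-])NC(=O)CC[C@H](NC(C)=O)C(=O)OCCCC`, was tested in a toxicity assay on KB cells (Homo sapiens) for cytotoxicity, read by fluorescence, with a stated time of 3 days; a lower number here means that less compound is needed, a higher number that more compound is needed for the effect. In this assay compound 1 gives only a limit, > 300 uM, so its true value is not pinned down. Two close relatives that keep the whole shared core and change only the group on the amine nitrogen were measured beside it. Compound 2, `CCCCOC(=O)CNC(=O)[C@H](CSc1ccc([N+](=O)[O-])cc1[N+](=O)[O-])NC(=O)CC[C@H](Nc1nc(N)nc(Cl)n1)C(=O)OCCCC`, carries 4-amino-6-chloro-1,3,5-triazin-2-yl in place of acetyl on that nitrogen; in this assay compound 2 also gives only a limit, > 300 uM. Compound 3, `CCCCOC(=O)CNC(=O)[C@H](CSc1ccc([N+](=O)[O-])cc1[N+](=O)[O-])NC(=O)CC[C@H](NC(=O)C(C)C)C(=O)OCCCC`, has isopropyl in place of methyl on the carbonyl carbon; in this assay compound 3 again gives only a limit, > 300 uM. None of the steps between them can be sized: a step that the two limits leave unreadable from compound 1 to compound 2, a step that the two limits leave unreadable from compound 1 to compound 3, and a step that the two limits leave unreadable from compound 2 to compound 3. All three values sit at the same place, namely (the limit of > 300 uM in this assay, at which 3 of the 3 values shown sit).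

Compound 4, `CCCCOC(=O)CNC(=O)[C@H](CSc1ccc([N+](=O)[O-])cc1[N+](=O)[O-])NC(=O)CC[C@H](NC(=O)/C=C/c1ccccc1)C(=O)OCCCC`, has not yet been measured. It differs from compound 1 in one place: 2-phenylethenyl in place of methyl on a carbonyl carbon. The two measured steps from compound 1 touch the same part of the molecule, yet both are unreadable, and none of the numbers shown points to a gain in cytotoxicity. The step of a number no higher from compound 1 to compound 4 (the limit leaves the size open) is therefore expected to be small or absent. Compound 4 is expected to give 300 uM, within 100 uM to 1000 uM, most likely once more as a limit.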

Compound 4, concentration for half-maximal effect: 34.4 uM
Compound 4: middle estimate off by 8.7-fold (0.94 log units), on the high side; the measured number lies below the stated range.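

On the carbonyl carbon of the acetamido group of compound 1, putting 2-phenylethenyl in place of methyl gives an at least 8.7-fold lower number from compound 1 to compound 4 (0.94 log units; beyond the scatter) in this assay and shows that the group at this position can change the result. The comparison with the other two compounds points the same way: 2-phenylethenyl in place of isopropyl gives an at least 8.7-fold lower number from compound 3 to compound 4 (0.94 log units; beyond the scatter) and (2-phenylethenyl)carbonyl in place of 4-amino-6-chloro-1,3,5-triazin-2-yl on the amine nitrogen gives an at least 8.7-fold lower number from compound 2 to compound 4 (0.94 log units; beyond the scatter). Going by these compounds alone, the steps among compound 1, compound 2 and compound 3 cannot be read, so compound 4 provides the first step of readable size, and the earlier values offered no sign of it: the limit of > 300 uM in this assay, at which 3 of the 4 values shown sit.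

The compounds shown do not separate the contribution of the phenyl ring from that of the double bond, which a 2-phenylethyl group or a plain phenyl group on the same carbonyl carbon could help to tease apart. On these data alone, it also remains open how much further the number would move with a substituted phenyl ring, such as one carrying a methoxy group or a chlorine atom.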